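This account rests on a few compounds, and the source may have more. Where it says the series, first, only, none or still open, it means among the compounds named here.

Compound 1 `N=C(S)CCn1ncccc1=S` and compound 3 `N=C(S)CCn1nc(-c2ccccc2)ccc1=O` belong to one series; the difference between their two cores is not broken down here. In a functional assay on the whole organism (stomach) for inhibition, with Rattus norvegicus as the target, at a dose of 100 mg/kg by the intraduodenal route (on this read-out lower numbers stand for less inhibition and higher numbers for more inhibition at the one dose given (going by the name of the read-out)), compound 1 gives 50% and compound 3 gives 53.7%. Compound 2 `CC(CC(=N)S)n1nc(-c2ccccc2)ccc1=O` carries methyl in place of hydrogen on a saturated chain carbon bound to an aromatic nitrogen and a saturated chain carbon and in this assay compound 2 gives 15.5%, so that a number 38.2 percentage points lower from compound 3 to compound 2 (beyond the scatter). Compound 4 `CC(Cn1ncccc1=S)C(=N)S` has not been measured; it carries methyl in place of hydrogen on a saturated chain carbon bound to a carbon with a double bond to nitrogen and a saturated chain carbon. This is the same kind of change as that from compound 3 to compound 2, but not the same: there the saturated chain carbon is bound to an aromatic nitrogen, here to a carbon with a double bond to nitrogen. A drop is expected for compound 4 because a number 38.2 percentage points lower from compound 3 to compound 2 (beyond the scatter), although the place differs; the estimated step is a number 22 percentage points lower from compound 1 to compound 4 (beyond the scatter). Compound 4 is therefore expected to give about 28%, between 8% and 50%.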

Compound 4, a percentage reported as inhibition, in the whole organism at one dose (the size of the read-out at that dose, not a potency): -1%
Compound 4: the middle estimate sits 29 percentage points above what was measured; the whole stated range lies above it.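

In this assay, methyl in place of hydrogen on a saturated chain carbon bound to a carbon with a double bond to nitrogen and a saturated chain carbon gives a number 51 percentage points lower from compound 1 to compound 4 (beyond the scatter). Set beside the earlier step, the drop carried over from one core to the other, with no difference beyond the scatter: the same change on two cores in this assay, a number 38.2 percentage points lower (beyond the scatter) from compound 3 to compound 2 and a number 51 percentage points lower (beyond the scatter) from compound 1 to compound 4, 12.8 percentage points apart, within the scatter of two such steps. For the compounds shown here, this rests on only two pairs, in which the methyl sits on differently bound chain carbons, and it shows neither why the number falls nor whether the drop would hold on any further core.

The compounds shown leave open whether an ethyl group or a longer chain in place of the methyl would lower the number as well. They also leave open how a carboxylic acid at the end of the chain would read.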